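The source may hold more compounds than are shown below. What is called first, only, known or untested is meant among the compounds shown, and "the series" means these compounds.

Measured so far:
- compound 1 `COc1ccc(OC)c(C(=O)/C=C/c2cn(-c3ccccc3)nc2-c2ccsc2)c1`: 3400 nM
- compound 2 `O=C(/C=C/c1cn(-c2ccccc2)nc1-c1ccncc1)c1cc[nH]c1`: 15700 nM

In a functional assay on HCT-116 cells (Homo sapiens) for inhibition, read by sulforhodamine B assay, with a stated time of 72 h (a higher number here means a weaker inhibitor, a lower number a stronger inhibitor), compound 2 gives 15700 nM, the higher of the two numbers in hand. Among the measured compounds shown here, compound 1, the only other measured member of the series, gives 3400 nM in this assay, and the gap between these two values lies beyond the scatter. For the measured compounds named here, compound 2 and compound 1 differ at two places at once, so no single-point step is available between them.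

Compound 3 `COc1ccc(OC)c(C(=O)/C=C/c2cn(-c3ccccc3)nc2-c2ccncc2)c1` is not yet measured. It is derived from compound 2 by one change: 2,5-dimethoxyphenyl in place of 1H-pyrrol-3-yl on a carbonyl carbon. The group that enters is the same one carried by compound 1 on its carbonyl carbon. Because compound 1 gives 3400 nM in this assay, a step downward from compound 2 is expected, and the expected step of a 3.5-fold lower number from compound 2 to compound 3 (0.54 log units; beyond the scatter) is put beyond the scatter. For compound 3 the expected value in this assay is 4500 nM, with a range from 1500 nM to 14000 nM.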

Compound 3, half-maximal inhibitory concentration: 900 nM
Beside the measured number, compound 3's estimate is 5.0-fold (0.70 log units) above it, outside the stated range (below it).
By their numbers in this assay, from the lowest: compound 3; then compound 1; then compound 2.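

In this assay, among the compounds shown here, with pyridin-4-yl on the aromatic carbon, 2,5-dimethoxyphenyl in place of 1H-pyrrol-3-yl on the carbonyl carbon gives a 17-fold lower number from compound 2 to compound 3 (1.24 log units; beyond the scatter) and so provides the first single-point reading at this position, a large step. With 2,5-dimethoxyphenyl on the carbonyl carbon, pyridin-4-yl in place of thiophen-3-yl on the aromatic carbon gives a 3.8-fold lower number from compound 1 to compound 3 (0.58 log units; beyond the scatter) and shows that this second position also moves the number, by a modest step. Nothing on hand accounts for either step.

Still open is whether the step at the carbonyl carbon needs both methoxy groups: an unsubstituted phenyl and a phenyl with a single methoxy group are not among the compounds shown. Also open, from the compounds shown here alone, is whether 1H-pyrrol-3-yl gives a similar number when paired with thiophen-3-yl.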